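Bromo for Fluoro on the Aryl Ring of Compound 3

A few compounds are considered here, and "the series" means these few. Any claim that something is new, unique, unknown or untested is made for them only; others in the source may bear on it.

Measured so far in a functional assay on A-375 cells (Homo sapiens) for cytotoxicity, read by CCK-8 assay, with a stated time of 24 h; a higher number here means a weaker inhibitor, a lower number a stronger inhibitor:
compound 1 `COc1ccccc1Oc1c(N)nc(-c2ccccc2)nc1Cl`: 7220 nM
compound 2 `COc1ccc(-c2nc(N)c(Oc3ccccc3OC)c(Cl)n2)cc1`: > 80000 nM
compound 3 `COc1ccccc1Oc1c(N)nc(-c2ccc(F)cc2)nc1Cl`: 28200 nM

Compound 2 gives only a limit in this assay, (the limit of > 80000 nM in this assay, at which 1 of the 3 values shown sits), and not a number. Among the numbers shown, compound 3 stands highest, with compound 1 nearest and giving the lower number, a 3.9-fold higher number from compound 1 to compound 3 (0.59 log units; beyond the scatter). The step of an at least 11-fold higher number from compound 1 to compound 2 (1.04 log units; beyond the scatter) is larger still, and an at least 2.8-fold lower number from compound 2 to compound 3 (0.45 log units; beyond the scatter) places compound 3 between the other two.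

Compound 4 `COc1ccccc1Oc1c(N)nc(-c2ccc(Br)cc2)nc1Cl` has not yet been measured. It differs from compound 3 by bromo in place of fluoro on an aromatic carbon, on an aromatic carbon of a six-membered aromatic ring of carbon only, para to a large group. The two steps that bear on it, a 3.9-fold higher number from compound 1 to compound 3 (0.59 log units; beyond the scatter) and an at least 11-fold higher number from compound 1 to compound 2 (1.04 log units; beyond the scatter), show that every group so far placed at this position gave a higher number than hydrogen, and the larger group gave the larger rise. Bromo is a single heavy atom like fluoro, so a step of modest size toward a higher number is expected in this assay, with the risk that only a limit is reported.

The estimate for compound 4 in this assay is 45000 nM, with a range of 14000 nM to 90000 nM. This estimate means an expected step of a 1.6-fold higher number from compound 3 to compound 4 (0.20 log units; within the scatter).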

Compound 4, half-maximal inhibitory concentration: 63 nM
Compound 4: the middle estimate sits 710-fold (2.85 log units) above what was measured; the measured number lies below the stated range.
By their numbers in this assay, from the lowest: compound 4; then compound 1; then compound 3. At a limit, above all of these: compound 2.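

In this assay, within the data shown here, the earlier compounds showed only rises over hydrogen at this place, on an aromatic carbon of a six-membered aromatic ring of carbon only, para to a large group; bromo reverses that direction, with a 110-fold lower number from compound 1 to compound 4 (2.06 log units; beyond the scatter), so a group here is not in itself a penalty. The change from 4-fluorophenyl to 4-bromophenyl gives a 450-fold lower number from compound 3 to compound 4 (2.65 log units; beyond the scatter), even though the two groups match in heavy-atom count, which shows that the identity of the halogen matters far more here than that count does, and that fluoro and bromo cannot be treated as interchangeable at this position. Compound 2 gives a limit and not a number, so an at least 1200-fold lower number from compound 2 to compound 4 (3.10 log units; beyond the scatter) can be read only as a bound: the limit of > 80000 nM in this assay, at which 1 of the 4 values shown sits.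

The compounds shown leave open whether the low number belongs to bromo alone or extends to other groups at this place, such as chloro, iodo, methyl, an amine or a carboxylic acid. They also cannot tell what separates bromo from fluoro, or whether the result of compound 4 holds beyond this single cell line.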